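Nitro in Place of Chloro: An Expected Cytotoxicity Value

The compounds below may be only part of what the source reports. "The series", "measured", "known", "first", "only" and "open" are said of these compounds alone.

Measured compounds:
compound 1, `Cc1ccc(-c2nn(-c3ccccc3)cc2C(=O)Nc2ccccc2)cc1`: 2360 nM
compound 2, `O=C(Nc1ccccc1)c1cn(-c2ccccc2)nc1-c1ccc(Cl)cc1`: 2180 nM

In a functional assay on HCT-116 cells (Homo sapiens) for cytotoxicity, read by MTT assay, with a stated time of 48 h (on this read-out lower numbers stand for stronger inhibition and higher numbers for weaker inhibition), compound 1 gives 2360 nM and compound 2 gives 2180 nM. Compound 2 and compound 1 sit within the scatter of each other: a 1.1-fold lower number from compound 1 to compound 2 (0.03 log units; within the scatter).

Compound 3, `O=C(Nc1ccccc1)c1cn(-c2ccccc2)nc1-c1ccc([N+](=O)[O-])cc1`, differs from compound 2 in one place: nitro in place of chloro on an aromatic carbon. Among the measured compounds shown here, only one measured step touches the same position, the exchange of methyl for chloro, and it stayed within the scatter. For the measured compounds named here, no measured compound carries a nitro group, so nothing shows how that group behaves here. The expectation for compound 3 in this assay is therefore a number close to that of compound 2, with a 1.0-fold higher number from compound 2 to compound 3 (0.00 log units; within the scatter) as the expected step, and wide bounds. Compound 3 is estimated at 2200 nM, between 900 nM and 5500 nM.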

Compound 3, half-maximal inhibitory concentration: 2010 nM
Estimate against measurement, compound 3: 1.1-fold (0.04 log units) above; the measured number falls inside the stated range.
By their numbers in this assay, from the lowest: compounds 3, 2 and 1 (each within the scatter of the next).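

In this assay nitro in place of chloro gives a 1.1-fold lower number from compound 2 to compound 3 (0.04 log units; within the scatter) and nitro in place of methyl gives a 1.2-fold lower number from compound 1 to compound 3 (0.07 log units; within the scatter) so three different groups at this position now give values that cannot be told apart. The earlier compounds shown here covered only methyl and chloro, each a single heavy atom on the ring, whereas nitro brings 3 heavy atoms and 2 hydrogen-bond acceptors, and this larger exchange also stays within the scatter. Nothing available explains why these values lie so close together.

As far as these compounds go, whether this holds for an amine, a carboxylic acid or a longer chain at the same position remains open. From the compounds shown here alone, the rest of the shared core is identical in all three compounds, so the effect of changes elsewhere also remains unknown.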